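Returning an Aryl Group to the Benzyl Arm

The compounds below may be only part of what the source reports. "The series", "measured", "known", "first", "only" and "open" are said of these compounds alone.

The measured compounds in an assay on isolated protein with Bile acid receptor (Homo sapiens) as the target (a higher number here means that more compound is needed for the effect, a lower number that less compound is needed), are:
compound 1, `COC(=O)/C=C/c1cccc(N(Cc2ccc(-c3cccc(Cl)c3)cc2)C(=O)C2CCCCC2)c1`: 94 nM
compound 2, `COC(=O)/C=C/c1ccc(CN(C(=O)C2CCCCC2)c2cccc(/C=C/C(=O)OC)c2)cc1`, for which only a limit of the assay is reported: > 1000 nM
compound 3, `CCOC/C=C/c1ccc(CN(C(=O)C2CCCCC2)c2cccc(/C=C/C(=O)OC)c2)cc1`: 198000 nM

Compound 3 stands highest of the two numbers given; its nearest neighbour is compound 1, reached through the step of a 2100-fold higher number from compound 1 to compound 3 (3.32 log units; beyond the scatter). The step of an at least 10-fold higher number from compound 1 to compound 2 (1.02 log units; beyond the scatter) is also large, and the step that the limit leaves unreadable from compound 2 to compound 3 cannot be read because of the limit of > 1000 nM in this assay, at which 1 of the 3 values shown sits.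

Compound 4, `COC(=O)/C=C/c1cccc(N(Cc2ccc(-c3ccc(SC)cc3)cc2)C(=O)C2CCCCC2)c1`, differs from compound 3 by 4-(methylsulfanyl)phenyl in place of 3-ethoxyprop-1-en-1-yl on an aromatic carbon. This change removes the group whose introduction carried the step of a 2100-fold higher number from compound 1 to compound 3 (3.32 log units; beyond the scatter) and puts back an aromatic ring on the same carbon, so that compound 4 resembles compound 1 far more closely than compound 3 does. The step from compound 1 to compound 3 therefore bears most directly, now run in reverse; the step from compound 1 to compound 2 shows that a non-aromatic chain at this carbon also gave a higher number.

Compound 4 is accordingly expected to show a large decrease, a 1700-fold lower number from compound 3 to compound 4 (3.22 log units; beyond the scatter). For compound 4 the estimate in this assay is 120 nM, with a range from 30 nM to 500 nM.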

Compound 4, half-maximal effective concentration: 69 nM
The estimate for compound 4 lay 1.7-fold (0.24 log units) above the measured number; the range from low to high includes it.
By their numbers in this assay, from the lowest: compounds 4 and 1 (each within the scatter of the next); then compound 3.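

In this assay, this carbon, para to a large group, now has a second aromatic ring to set beside the 3-chlorophenyl group of compound 1, and a 1.4-fold lower number from compound 1 to compound 4 (0.13 log units; within the scatter) shows that this assay does not separate the two rings, although their substituents differ in both identity and ring position. Among the compounds shown here, the recovery seen in a 2900-fold lower number from compound 3 to compound 4 (3.46 log units; beyond the scatter) means that the low number is no longer tied to the single 3-chlorophenyl group: both compounds with an aromatic ring here sit far from compound 3, which carries the 3-ethoxyprop-1-en-1-yl chain. The 2-(methoxycarbonyl)ethenyl chain gives the same picture in an at least 14-fold lower number from compound 2 to compound 4 (1.16 log units; beyond the scatter), a step that starts from a limit of the assay and not from a number: the limit of > 1000 nM in this assay, at which 1 of the 4 values shown sits.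

The compounds shown leave open whether the ring must be aromatic, since a saturated cyclohexyl ring at this carbon would separate aromaticity from the presence of a ring as such. They also leave open how far the outer ring tolerates other substituents, such as a carboxylic acid or an amine, and whether a pyridine ring could replace it.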